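Chloro in Place of Nitro, Tried a Second Time

The source may hold more compounds than are shown below. What is called first, only, known or untested is meant among the compounds shown, and "the series" means these compounds.

Of the compounds shown here, three have been measured in a physicochemical assay, read by spectrophotometry, with a stated time of 30 min; a lower number here means a stronger inhibitor, a higher number a weaker inhibitor. Compound 1 `O=[N+]([O-])c1cccc(Cn2cc(COc3ccccc3)nn2)c1` gives 25.3 ug/mL in this assay. Compound 2 `Clc1cccc(Cn2cc(COc3ccccc3)nn2)c1` gives 27.3 ug/mL in this assay. Compound 3 `O=[N+]([O-])c1ccc(Cn2cc(COc3c(Cl)cc(Cl)cc3Cl)nn2)cc1` gives 28.9 ug/mL in this assay.

Compound 2 arises from compound 1 by a single change, (chloro in place of nitro on an aromatic carbon), and the step it made was a 1.1-fold higher number from compound 1 to compound 2 (0.03 log units; within the scatter). Compound 3 shares much with compound 1, but the difference between the two cores is not broken down here; what the values show is that compound 3 and compound 1, like compound 3 and compound 2, lie within the usual scatter of each other in this assay.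

Compound 4 `Clc1ccc(Cn2cc(COc3c(Cl)cc(Cl)cc3Cl)nn2)cc1` has not yet been measured. It differs from compound 3 by chloro in place of nitro on an aromatic carbon. Within the data shown here, this is the same kind of change as the one from compound 1 to compound 2, though not the same: in compound 1 the group sits meta to a large group, while in compound 3 it sits para to a large group.

Because a 1.1-fold higher number from compound 1 to compound 2 (0.03 log units; within the scatter) stayed within the scatter, the step of a 1.1-fold higher number from compound 3 to compound 4 (0.03 log units; within the scatter) is expected to be of a similar size in this assay, resting on that single earlier pair. On that basis compound 4 is estimated to give about 31 ug/mL in this assay, with a likely range from 18 ug/mL to 55 ug/mL.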

Compound 4, half-maximal inhibitory concentration: 27.2 ug/mL
Beside the measured number, compound 4's estimate is 1.1-fold (0.06 log units) above it; the measured number falls inside the stated range.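

In this assay, chloro in place of nitro on an aromatic carbon gave a 1.1-fold lower number from compound 3 to compound 4 (0.03 log units; within the scatter), and on the core of compound 1 the same kind of change had given a 1.1-fold higher number from compound 1 to compound 2 (0.03 log units; within the scatter). The change has thus been read on two cores, here with the group para to a large group, and neither step lies beyond the scatter, even though a nitro of 3 heavy atoms and 2 hydrogen-bond acceptors gives way to a chloro of 1 heavy atom and no hydrogen-bond acceptors. This does not show that the change would stay as small on a third core, as it rests on two pairs alone, and nothing at hand bears on why the two steps came out as they did.

On the ring that carries this change, the compounds shown hold only nitro or chloro, which leaves open whether an amine or a carboxylic acid in that place would also stay within the scatter. Also open, on these data alone, is whether a methoxy group or a longer chain there would give a step beyond the scatter on either core, and whether such a step would carry from one core to the other.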